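The source may report more compounds than this note shows. Statements on the series, on what has been measured and on what is new or still open speak of the compounds shown alone.

Measured compounds:
compound 1 `CC(C)[C@H](C(=O)Nc1ccccc1)c1ccc(Cl)cc1`
compound 2 `CC(C)[C@H](C(=O)Nc1ccon1)c1ccc(Cl)cc1`

In a functional assay on CHO cells for agonist activity at Free fatty acid receptor 2 (Homo sapiens), read by cAMP accumulation (a lower number here means a smaller maximal response, a higher number a larger maximal response), compound 1 gives < 30%, a limit of the assay rather than a number. Going by the values given here, compound 2 gives 90% in this assay, the only number in the set. The value of compound 1 is the one that sits at a limit (the limit of < 30% in this assay, at which 1 of the 2 values shown sits). Among the compounds with values here, the sole measured step, a number at least 60 percentage points higher from compound 1 to compound 2 (beyond the scatter), is the exchange of phenyl for 1,2-oxazol-3-yl on the amide-type nitrogen.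

Compound 3 `CC(C)[C@H](C(=O)Nc1ncc(C#N)s1)c1ccc(Cl)cc1` carries at the same nitrogen the change (5-cyano-1,3-thiazol-2-yl in place of 1,2-oxazol-3-yl on an amide-type nitrogen). Within the data shown here, both the leaving and the entering group are five-membered aromatic rings with 2 hetero atoms, so the measured step, which moved from phenyl to such a ring, bears on it only indirectly; no step compares two such rings. Compound 3 is therefore expected to stay near compound 2, with the step of a number 10 percentage points lower from compound 2 to compound 3 (within the scatter) estimated as within the scatter or modestly lower. The estimate for compound 3 in this assay is 80%, with a range from 50% to 105%.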

Compound 3, largest response reached (reported as efficacy), in percent of the reference or control that the assay uses: 105%
Beside the measured number, compound 3's estimate is 25 percentage points below it; the measured number falls inside the stated range.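

In this assay, exchanging 1,2-oxazol-3-yl for 5-cyano-1,3-thiazol-2-yl on the amide-type nitrogen gives a number 15 percentage points higher from compound 2 to compound 3 (beyond the scatter), so this position still responds among five-membered aromatic rings with 2 hetero atoms, and the two rings are not interchangeable here. Replacing phenyl with the same 5-cyano-1,3-thiazol-2-yl gives a number at least 75 percentage points higher from compound 1 to compound 3 (beyond the scatter). Compound 1 is a limit of the assay and not a number, so that step has only a lower bound: the limit of < 30% in this assay, at which 1 of the 3 values shown sits.

Going by these compounds, compound 3 changes the ring and adds the cyano group in a single exchange, so the share of each in the step remains open. Also open, on these data alone, is how plain 1,3-thiazol-2-yl, or the same ring carrying an amine or a carboxylic acid in place of the cyano group, would read.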